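Ring enlargement on the amide of compound 1

The source may report more compounds than this note shows. Statements on the series, on what has been measured and on what is new or still open speak of the compounds shown alone.

Measured so far:
compound 1 `C[C@@H]1N[C@H](C(=O)N2CCC[C@H]2C#N)C[C@@H]1C(=O)N1CCCC1` — 88%
compound 2 `CCNC(=O)[C@@H]1CN[C@H](C(=O)N2CCC[C@H]2C#N)C1` — 19%
compound 3 `CCN(C)C(=O)[C@@H]1CN[C@H](C(=O)N2CCC[C@H]2C#N)C1` — 34%

In an assay on the whole organism (plasma, strain Sprague-Dawley) for inhibition of Dipeptidyl peptidase 4 (Rattus norvegicus), with a stated time of 10 h, at a dose of 1 mg/kg by the oral route (a lower number here means less inhibition, a higher number more inhibition at the dose given (going by the name of the read-out)), compound 1 gives 88%, the highest of the three numbers; compound 3 stands nearer and compound 2 furthest, both beyond the scatter. Among the compounds with values here, the only step between measured compounds, a number 15 percentage points higher from compound 2 to compound 3 (beyond the scatter), shows a modest rise on going from a secondary to a tertiary amide.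

Compound 4 `C[C@@H]1N[C@H](C(=O)N2CCC[C@H]2C#N)C[C@@H]1C(=O)N1CCCCC1` differs from compound 1 by piperidin-1-yl in place of pyrrolidin-1-yl on a carbonyl carbon. Within the data shown here, both compounds carry a tertiary cyclic amide, so the one measured step bears on this change only indirectly; no measured pair varies the size of the amide ring. Compound 4 is therefore expected to stay close to compound 1, with a step of a number 8 percentage points lower from compound 1 to compound 4 (within the scatter) that may lie within the scatter or slightly below. The estimate for compound 4 in this assay is 80%, ranging from 55% to 95%.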

Compound 4, a percentage reported as inhibition, in the whole organism at one dose (the size of the read-out at that dose, not a potency): 81%
For compound 4 the middle estimate is 1 percentage points below the measured one; low and high end bracket the measured number.
By their numbers in this assay, from the lowest: compound 2; then compound 3; then compounds 4 and 1 (each within the scatter of the next).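

Piperidin-1-yl in place of pyrrolidin-1-yl on a carbonyl carbon gives a number 7 percentage points lower from compound 1 to compound 4 (within the scatter) in this assay. Within the data shown here, this is the first measured variation of ring size at this position, and the six-membered ring leaves the read-out within the scatter of the five-membered one. No supporting measurement accounts for this result.

Open, on these data alone, is how morpholin-4-yl, with a second ring hetero atom, or open-chain diethylamino would behave on this carbonyl carbon. Also open, as far as these compounds go, is whether larger rings, such as azepan-1-yl, keep the read-out at this level.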